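The source may hold more compounds than are shown below. What is called first, only, known or untested is meant among the compounds shown, and "the series" means these compounds.

Of the compounds shown here, two have been measured in an ADME assay on the whole organism (Macaca fascicularis) for pharmacokinetics, read by LC-MS, using cassette dosing, at a dose of 1 mg/kg by the oral route; a lower number here means less compound in the circulation, a higher number more compound in the circulation at the dose given. Compound 1 `CCCCN(c1nc2c(NS(C)(=O)=O)cccc2o1)[C@H](C)c1ccc(-c2ccccc2-c2nnn[nH]2)cc1` gives 49.9 nM. Compound 2 `CCCCN(c1nc2c(C(=O)O)cccc2o1)[C@H](C)c1ccc(-c2ccccc2-c2nnn[nH]2)cc1` gives 238 nM, the higher of the two numbers, after a 4.8-fold higher number from compound 1 to compound 2 (0.68 log units; beyond the scatter).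

Compound 3 `CCCCN(c1nc2c(-c3ccccn3)cccc2o1)[C@H](C)c1ccc(-c2ccccc2-c2nnn[nH]2)cc1` differs from compound 2 by pyridin-2-yl in place of carboxy on an aromatic carbon. For the measured compounds named here, no measured step bears directly on this change; the only step on record, a 4.8-fold higher number from compound 1 to compound 2 (0.68 log units; beyond the scatter), concerns a different exchange at the same aromatic carbon and offers no guide to direction. For compound 3 the step of a 2.0-fold lower number from compound 2 to compound 3 (0.30 log units; within the scatter) is therefore expected to be small and uncertain. Compound 3 is estimated at 120 nM, with a range of 30 nM to 500 nM.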

Compound 3, maximal plasma concentration: 124 nM
Beside the measured number, compound 3's estimate is 1.0-fold (0.01 log units) below it, within the range that was stated.
By their numbers in this assay, from the lowest: compound 1; then compounds 3 and 2 (each within the scatter of the next).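

In this assay, a ring group of six heavy atoms at this aromatic carbon reads level with carboxy, with a 1.9-fold lower number from compound 2 to compound 3 (0.28 log units; within the scatter) as the step. Set against methanesulfonamido, the same pyridin-2-yl gives a 2.5-fold higher number from compound 1 to compound 3 (0.40 log units; beyond the scatter), leaving compound 1 as the one compound separated from both others by steps beyond the scatter. No measurement on record accounts for these numbers.

As far as these compounds go, whether an amine or a pyridin-3-yl at this carbon would read with compound 1 or with compound 2 and compound 3 stays open.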